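Chlorinated aryl pyridines: swapping furan-2-yl for 4-methylphenyl

The compounds below may be only part of what the source reports. "The series", "measured", "known", "first", "only" and "open" are said of these compounds alone.

- Compound 1 `Cc1ccc(-c2cc(-c3ccoc3)cc(-c3ccc(Cl)s3)n2)cc1` gives 28700 nM
- Compound 2 `Clc1ccc(-c2cc(-c3ccco3)nc(-c3ccc(Cl)s3)c2)o1` gives > 50000 nM (a limit)

In a functional assay on HeLa cells (Homo sapiens) for cytotoxicity, read by ELISA, with a stated time of 4 days (a lower number here means a stronger inhibitor, a higher number a weaker inhibitor), compound 2 stands only at a limit (> 50000 nM) and has no number. Compound 3 `Cc1ccc(-c2cc(-c3ccc(Cl)o3)cc(-c3ccc(Cl)s3)n2)cc1` differs from compound 2 at one place: 4-methylphenyl in place of furan-2-yl on an aromatic carbon. Going by the values given here, no measured pair isolates this change. Compound 1 (28700 nM) carries the 4-methylphenyl group, so a modest move towards stronger inhibition is expected. The expected step is an at least 2.0-fold lower number from compound 2 to compound 3 (0.30 log units; that floor lies within the scatter) in this assay and remains uncertain. For compound 3 the estimated value is 25000 nM (range 9000 nM to 50000 nM).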

Compound 3, half-maximal inhibitory concentration: > 50000 nM
Compound 3: a limit, no number (the forecaster's own chance of this, stated with the estimate: 25%); at least 2.0-fold (0.30 log units) between middle value and limit.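

In this assay, 4-methylphenyl in place of furan-2-yl next to the ring nitrogen brings no readable gain: both values are limits, so the step between compound 2 and compound 3 cannot be read. With 4-methylphenyl held, 5-chlorofuran-2-yl in place of furan-3-yl gives an at least 1.7-fold higher number from compound 1 to compound 3 (0.24 log units; that floor lies within the scatter), so only compound 1 keeps a number. Most of the set now sits at the top of the read-out: the limit of > 50000 nM in this assay, at which 2 of the 3 values shown sit.

Still open, going by these compounds, is whether an amine in place of 4-methylphenyl next to the ring nitrogen would bring the series to a number inside the range of the assay.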